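The source may hold more compounds than are shown below. What is called first, only, known or untested is meant among the compounds shown, and "the series" means these compounds.

In an assay on isolated protein for binding affinity to leukotriene B4 receptor 1 (Homo sapiens), tested at 1 uM (on this read-out lower numbers stand for less inhibition and higher numbers for more inhibition at the one concentration tested (going by the name of the read-out)), the measured compounds gave: compound 1 `CCCc1cc(C(C)=O)c(O)cc1OCCCCC#N`, 37%; compound 2 `COCc1cc(C(C)=O)c(O)cc1OCCCCCCC#N`, 7%; compound 3 `CC(=O)c1cc(CO)c(OCCCCCCC#N)cc1O`, 8%.

Compound 1 stands highest of the three, beyond the scatter from both compound 2 and compound 3. Compound 4 `CC(=O)c1cc(CC(C)O)c(OCCCCC#N)cc1O` differs from compound 1 by hydroxy in place of hydrogen on a saturated chain carbon bound to two saturated chain carbons. For the measured compounds named here, the only measured single-point step, a number 1 percentage points higher from compound 2 to compound 3 (within the scatter), concerns a different change, hydrogen in place of methyl on an oxygen, and lies within the scatter; no measured step introduces a hydroxy, so it bears on this change only loosely. The expectation for compound 4 is therefore a step of a number 5 percentage points lower from compound 1 to compound 4 (within the scatter), not beyond the scatter. Compound 4 is estimated at 32%, with a range from 15% to 50%.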

Compound 4, a percentage reported as inhibition, at one concentration (the size of the read-out at that concentration, not a potency): 6%
Compound 4: middle estimate off by 26 percentage points, on the high side, outside the stated range (below it).
By their numbers in this assay, from the lowest: compounds 4, 2 and 3 (each within the scatter of the next); then compound 1.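

In this assay, for the compounds shown here, changing propyl to 2-hydroxypropyl gives a number 31 percentage points lower from compound 1 to compound 4 (beyond the scatter), the only measured step at this position and the only one that adds a hydroxy. A single added oxygen on this saturated chain carbon, bound to two saturated chain carbons, is therefore enough to remove most of the inhibition seen with plain propyl. Nothing measured here explains the loss. On these data alone, whether an amine or a carboxylic acid on the same carbon would lower the number too remains open. So does whether a hydroxy further along a longer chain would do the same.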